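Oxetane Carbamates on a Benzimidazole Core: Cytotoxicity in Prostate Cells

This account rests on a few compounds, and the source may have more. Where it says the series, first, only, none or still open, it means among the compounds named here.

Measured so far:
- compound 1, `CCCSc1ccc2[nH]c(NC(=O)OCCCN(C)C)nc2c1`: 95.5%
- compound 2, `CCCSc1ccc2[nH]c(NC(=O)OC3COC3)nc2c1`: 95.2%

In a functional assay on PC-3 cells (Homo sapiens) for cytotoxicity, read by MTT assay, with a stated time of 72 h, tested at 1 uM (a higher number here means a weaker effect of the compound at the concentration tested, a lower number a stronger effect), compound 1 gives 95.5%, and compound 2 gives 95.2%. Compound 2 thus sits within the scatter of compound 1; neither number shows more than a faint effect at the concentration tested. Among the measured compounds shown here, the only measured step, a number 0.3 percentage points lower from compound 1 to compound 2 (within the scatter), was within the scatter, although it exchanged a whole side group on the oxygen next to the carbonyl group.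

Compound 3, `CCCSc1ccc2[nH]c(NC(=O)OCC3(C)COC3)nc2c1`, changes that same position again: (3-methyloxetan-3-yl)methyl in place of oxetan-3-yl on an oxygen next to a carbonyl group. For the measured compounds named here, since the one measured step at this position left the number where it was, the expected step of a number 1.2 percentage points lower from compound 2 to compound 3 (within the scatter) is none beyond the scatter. Compound 3 is estimated to give 94% in this assay, with a likely range from 84% to 100%.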

Compound 3, a percentage reported as activity, at one concentration (the size of the read-out at that concentration, not a potency): 87.2%
Beside the measured number, compound 3's estimate is 6.8 percentage points above it; the measured number falls inside the stated range.
By their numbers in this assay, from the lowest: compounds 3, 2 and 1 (each within the scatter of the next).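

In this assay, the larger (3-methyloxetan-3-yl)methyl group on the oxygen next to a carbonyl group gives a number 8 percentage points lower from compound 2 to compound 3 (within the scatter), and the comparison with the side group of compound 1 gives a number 8.3 percentage points lower from compound 1 to compound 3 (within the scatter). Even with a methyl-bearing oxetane on a longer link, then, neither step leaves the scatter, so the three side groups shown at this position cannot be told apart at the one concentration tested. No supporting measurement bears on this result.

As far as these compounds go, whether a phenyl ring or a carboxylic acid on this oxygen would give a step beyond the scatter remains open. Also open, from the compounds shown here alone, is how these compounds would behave at other concentrations, since a single-concentration read-out gives no potency.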